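Removing One Chain from Compound 2

The source may report more compounds than this note shows. Statements on the series, on what has been measured and on what is new or still open speak of the compounds shown alone.

For the measured compounds named here, in an ADME assay on NIH3T3 cells (Mus musculus) for cytotoxicity, read by neutral red uptake, with a stated time of 48 h (on this read-out lower numbers stand for higher toxicity in this test and higher numbers for lower toxicity in this test), compound 1 `CCCCCCCC/C=C/c1c(C)c(/C=C/CCCCCCCC)c2[n+](c1C)CCC2` gives 2.5 uM and compound 2 `CCCCCCCC/C=C\c1c(C)c(/C=C/CCCCCCCC)c(C)[n+]2c1CCC2` gives 3.2 uM, so compound 2 stands level with its only neighbour. That step, a 1.3-fold higher number from compound 1 to compound 2 (0.11 log units; within the scatter), comes with the fact that compounds 1 and 2 differ only in the configuration as drawn. The next structure is compound 3 `CCCCCCCC/C=C\c1c(C)cc(C)[n+]2c1CCC2`, which carries a hydrogen atom in place of a group of 10 heavy atoms (10 carbon; no ring), on an aromatic carbon. The measured step removes no group, so it sets no size for this change and the expectation stays loose. A step to a higher number in this assay is expected, a 3.8-fold higher number from compound 2 to compound 3 (0.57 log units; beyond the scatter). For compound 3 the estimated value is 12 uM, within an expected range of 3.5 uM to 50 uM.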

Compound 3, half-maximal toxic concentration: 1.9 uM
Beside the measured number, compound 3's estimate is 6.3-fold (0.80 log units) above it; the whole stated range lies above it.
By their numbers in this assay, from the lowest: compounds 3, 1 and 2 (each within the scatter of the next).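

In this assay, a hydrogen atom in place of the group of 10 carbon on the aromatic carbon gives a 1.7-fold lower number from compound 2 to compound 3 (0.23 log units; within the scatter), so at this position the read-out stays within the scatter with that chain gone. For the compounds shown here, compound 3 keeps its one remaining dec-1-en-1-yl group, and with that single chain the number stays level with that of compound 2. Nothing at hand explains this result. The compounds shown leave open how a shorter chain, an amine or a carboxylic acid at this position would read, and what losing the remaining dec-1-en-1-yl group would do.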